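Methoxy gives way to nitro on compound 3

A few compounds are considered here, and "the series" means these few. Any claim that something is new, unique, unknown or untested is made for them only; others in the source may bear on it.

Compound 1 `O=C1COCC(=O)N1CCCCN1CCN(c2ncccc2-c2ccccc2)CC1`: > 63 mg/kg (limit)
Compound 2 `N#Cc1cccnc1N1CCN(CCCCN2C(=O)CSC2=O)CC1`: > 100 mg/kg (limit)
Compound 3 `COc1cccnc1N1CCN(CCCCN2C(=O)SC3(CCCC3)C2=O)CC1`: < 57 mg/kg (limit)

In a functional assay on the whole organism for inhibition, with Rattus norvegicus as the target (on this read-out lower numbers stand for an effect already at smaller amounts and higher numbers for an effect only at larger amounts of compound), compound 3 gives < 57 mg/kg, which is a limit and not a number. Compound 1 and compound 2 are likewise known only as limits, so the three cannot be ranked precisely against a measured number.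

Compound 4 `O=C1SC2(CCCC2)C(=O)N1CCCCN1CCN(c2ncccc2[N+](=O)[O-])CC1` has nitro in place of methoxy on an aromatic carbon, two atoms from the ring nitrogen: nitro in place of methoxy on an aromatic carbon. For the measured compounds named here, no measured pair shows the effect of this swap, so no step beyond the scatter is expected, in either direction. The expected change is a step that the limit leaves unreadable from compound 3 to compound 4. For compound 4 the estimate is 50 mg/kg, with an expected range from 15 mg/kg to 120 mg/kg.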

Compound 4, dose for half-maximal effect: 43.6 mg/kg
Beside the measured number, compound 4's estimate is 1.1-fold (0.06 log units) above it; low and high end bracket the measured number.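

The step from compound 3 to compound 4 cannot be read, because compound 3 stands only as a limit: the limit of < 57 mg/kg in this assay, at which 1 of the 4 values shown sits.

The compounds shown leave open how large the effect of nitro in place of methoxy is, and in which direction it goes.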